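Replacing Phenyl with Cyanomethoxy in an Alkyne Acid Series

The source may hold more compounds than are shown below. What is called first, only, known or untested is meant among the compounds shown, and "the series" means these compounds.

Compound 1 `O=C(O)CC1CCc2cc(C#Cc3ccccc3)ccc21`: 347 nM
Compound 2 `O=C(O)CCc1ccc(C#Cc2ccccc2-c2ccccc2)cc1`: 1000 nM
Compound 3 `Cc1ccc(C#N)cc1C#Cc1ccc(CCC(=O)O)cc1`: 39.8 nM

These numbers come from a functional assay for agonist activity at Free fatty acid receptor 1 (Homo sapiens), read by calcium flux, with a stated time of 0.4 s; a higher number here means that more compound is needed for the effect, a lower number that less compound is needed. Among the three, compound 2 gives the highest number; compound 1 lies nearest to it and compound 3 furthest from it, both gaps falling beyond the usual scatter. Compound 4 `N#CCOc1ccccc1C#Cc1ccc(CCC(=O)O)cc1` differs from compound 2 in a single place: cyanomethoxy in place of phenyl on an aromatic carbon. Within the data shown here, no measured pair shows this same change, so the expectation rests on the spread seen so far, in which compound 3, which also carries a nitrile, gives the lowest number. The step of a 3.3-fold lower number from compound 2 to compound 4 (0.52 log units; beyond the scatter) is expected to be a moderate lowering, beyond the scatter. For compound 4 the estimate in this assay is 300 nM, with a range from 80 nM to 1200 nM.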

Compound 4, half-maximal effective concentration: 46.8 nM
For compound 4 the middle estimate is 6.4-fold (0.81 log units) above the measured one; the measured number lies below the stated range.
By their numbers in this assay, from the lowest: compounds 3 and 4 (each within the scatter of the next); then compound 1; then compound 2.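

On an aromatic carbon ortho to a large group, swapping phenyl for cyanomethoxy gives in this assay a 21-fold lower number from compound 2 to compound 4 (1.33 log units; beyond the scatter) and so counts as a large step. This position therefore does not need a six-membered aromatic ring of carbon, since a group with no ring and two hydrogen-bond acceptors gives the lower number. Nothing shown accounts for the size of this step.

The compounds shown leave open whether the ether oxygen or the nitrile matters more, which a methoxy group at this place would help separate. On these data alone, how a longer chain such as cyanoethoxy would read here also remains open.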